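Removing One Chloro from a Dichloro Core

This account rests on a few compounds, and the source may have more. Where it says the series, first, only, none or still open, it means among the compounds named here.

Within the data shown here, compound 2 `ClCc1cccc(Cn2cnc3nc(Cl)nc(Cl)c32)c1` gives 1690 nM in a functional assay on NCI-H460 cells (Homo sapiens) for cytotoxicity, read by sulforhodamine B assay, with a stated time of 48 h (a higher number here means a weaker inhibitor of growth, a lower number a stronger inhibitor of growth), the lowest of the two numbers measured so far, while compound 1 `Nc1nc(Cl)c2ncn(Cc3ccccc3CCl)c2n1` gives 5620 nM, a gap beyond the usual scatter. Compound 3 `ClCc1cccc(Cn2cnc3ncnc(Cl)c32)c1` differs from compound 2 in one place: hydrogen in place of chloro on an aromatic carbon. Among the measured compounds shown here, no measured pair shows this exact change, so its effect has not been seen directly. The expected step of a 1.8-fold higher number from compound 2 to compound 3 (0.25 log units; within the scatter) is modest and toward a weaker inhibitor of growth. Compound 3 is therefore estimated at 3000 nM in this assay, with a range from 1000 nM to 9000 nM.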

Compound 3, concentration for 50% growth inhibition: 2080 nM
Compound 3: the middle estimate sits 1.4-fold (0.16 log units) above what was measured; the measured number falls inside the stated range.
By their numbers in this assay, from the lowest: compounds 2 and 3 (each within the scatter of the next); then compound 1.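

Putting hydrogen in place of chloro on the aromatic carbon between two ring nitrogen atoms gives a 1.2-fold higher number from compound 2 to compound 3 (0.09 log units; within the scatter) in this assay. Among these compounds, this is the first pair that differs in one place only, and it shows that this chloro can go without a change beyond the scatter. No measurement shown here accounts for this result.

Going by these compounds, what a methoxy group or a fluoro on this same carbon would do in this assay remains open. So does the effect of changing the remaining chloro on the ring.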